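The compounds below may be only part of what the source reports. "The series", "measured", "known", "first", "only" and "open" are said of these compounds alone.

Series notes. Compound 1 `COc1ccc(-c2cc(NC(=O)CCC(=O)NCC(=O)NC(C)(C)C)nc(-c3ccc(OC)cc3)n2)cc1` in an assay on HeLa cells for displacement of a labelled ligand from adenosine receptor A3 (Homo sapiens), read by fluorescence polarization, with a stated time of 30 min (on this read-out higher numbers stand for weaker inhibition and lower numbers for stronger inhibition), gives 15000 nM. Compound 2 `COc1ccc(-c2cc(NC(=O)CCC(=O)NCC(=O)NC3CCCCC3)nc(-c3ccc(OC)cc3)n2)cc1` differs from it by cyclohexyl in place of tert-butyl on an amide-type nitrogen; in this assay compound 2 gives 35100 nM. The step of a 2.3-fold higher number from compound 1 to compound 2 (0.37 log units; beyond the scatter) thus runs toward weaker inhibition. Compound 3 `COc1ccc(-c2cc(NC(=O)COCC(=O)N(C)CC(=O)NC(C)(C)C)nc(-c3ccc(OC)cc3)n2)cc1` carries a different linker; the difference between the core of compound 1 and the core of compound 3 is not broken down here. In this assay, among the compounds with values here, compound 3 gives 7200 nM, the lowest of the three numbers so far, with compound 1 and compound 2 both beyond the scatter from it.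

Compound 4 `COc1ccc(-c2cc(NC(=O)COCC(=O)N(C)CC(=O)NC3CCCCC3)nc(-c3ccc(OC)cc3)n2)cc1` is not yet measured. It differs from compound 3 by cyclohexyl in place of tert-butyl on an amide-type nitrogen, the same change as that made from compound 1 to compound 2, at a place described in identical words. Within the data shown here, only one measured instance of this change exists, so any expectation rests on compound 1 and compound 2 alone, with no check on whether the core of compound 3 carries it the same way. For compound 4 the expected step in this assay is a 2.2-fold higher number from compound 3 to compound 4 (0.35 log units; beyond the scatter), because the measured step of a 2.3-fold higher number from compound 1 to compound 2 (0.37 log units; beyond the scatter) ran the same way on the other core. Among the measured compounds shown here, the estimate for compound 4 in this assay is 16000 nM, with a range from 7000 nM to 40000 nM allowing for the single precedent and the weak potency level at which these numbers sit.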

Compound 4, inhibition constant: 10100 nM
For compound 4 the middle estimate is 1.6-fold (0.20 log units) above the measured one; the range from low to high includes it.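

In this assay, cyclohexyl in place of tert-butyl on an amide-type nitrogen gives a 1.4-fold higher number from compound 3 to compound 4 (0.15 log units; within the scatter), so on this core the two groups cannot be told apart. Set beside the earlier instance of the same change, the new step does not differ measurably from it: the same change on two cores in this assay, a 2.3-fold higher number (0.37 log units; beyond the scatter) from compound 1 to compound 2 and a 1.4-fold higher number (0.15 log units; within the scatter) from compound 3 to compound 4, 1.7-fold (0.22 log units) apart, within the scatter of two such steps. This shows that the change carried from the core of compound 1 to the core of compound 3 without a detectable difference between the two cores, but it does not show that the step has one fixed size, since the step on the first core lies beyond the scatter and the step on the second lies within it, and two pairs on two cores support no general rule for the series.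

The compounds shown leave open how other groups on that amide-type nitrogen would read, for example isopropyl, phenyl or benzyl, or a chain ending in a carboxylic acid or an amine. They also leave open whether the same change would carry onto a core with a longer linker chain, or onto one bearing groups other than methoxy on its aromatic rings.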